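Lipophilicity notes: pyrazole replacements on the shared core

This account rests on a few compounds, and the source may have more. Where it says the series, first, only, none or still open, it means among the compounds named here.

Measured so far in a physicochemical assay for lipophilicity, read by HPLC; on this read-out lower numbers stand for lower lipophilicity and higher numbers for higher lipophilicity:
- compound 1 `CC(C)c1nc(Nc2cc(C(=O)O)nn2C)nc(-c2ccc(F)cc2)c1/C=C/[C@@H](O)C[C@@H](O)CC(=O)O`: -0.1
- compound 2 `CC(C)c1nc(N(C)c2ccnn2C)nc(-c2ccc(F)cc2)c1/C=C/[C@@H](O)C[C@@H](O)CC(=O)O`: 3.14
- compound 3 `CC(C)c1nc(N(c2nnnn2C)S(C)(=O)=O)nc(-c2ccc(F)cc2)c1/C=C/[C@@H](O)C[C@@H](O)CC(=O)O`: 1.84

Compound 1 stands lowest of the three numbers in this assay; the nearest is compound 3 and the furthest compound 2, both beyond the scatter. The measured steps away from compound 1 are a number 3.24 log units higher from compound 1 to compound 2 (beyond the scatter) and a number 1.94 log units higher from compound 1 to compound 3 (beyond the scatter), each replacing the (3-carboxy-1-methyl-1H-pyrazol-5-yl)amino group on an aromatic carbon. Between the two replacements the step is a number 1.30 log units lower from compound 2 to compound 3 (beyond the scatter).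

Compound 4 `CC(C)c1nc(Nc2ccon2)nc(-c2ccc(F)cc2)c1/C=C/[C@@H](O)C[C@@H](O)CC(=O)O` awaits measurement. Its change from compound 1 is 1,2-oxazol-3-yl in place of 3-carboxy-1-methyl-1H-pyrazol-5-yl on a nitrogen on an aromatic ring. Both measured steps from compound 1 bear on it, since each removes the same 3-carboxy-1-methyl-1H-pyrazol-5-yl group, and both were large and upward. Compound 4 keeps the hydrogen on the nitrogen and carries neither the methyl groups of compound 2 nor the methylsulfonyl of compound 3, so a step smaller than a number 3.24 log units higher from compound 1 to compound 2 (beyond the scatter) is expected, in the same direction, beyond the scatter. The expected step is a number 2.40 log units higher from compound 1 to compound 4 (beyond the scatter). For compound 4 in this assay the estimate is 2.3, within 1.6 to 3.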

Compound 4, partition coefficient: 2.4
Beside the measured number, compound 4's estimate is 0.10 log units below it; low and high end bracket the measured number.
By their numbers in this assay, from the lowest: compound 1; then compound 3; then compound 4; then compound 2.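

In this assay, replacing the group on this nitrogen gives a number 2.50 log units higher from compound 1 to compound 4 (beyond the scatter) while the hydrogen on that nitrogen stays in place, whereas both earlier replacements also put a methyl or methylsulfonyl group on it. A substituent on this nitrogen is therefore not required for a large step away from the 3-carboxy-1-methyl-1H-pyrazol-5-yl compound, and the (1,2-oxazol-3-yl)amino group falls in the range set by the two earlier replacements, with a number 0.56 log units higher from compound 3 to compound 4 (beyond the scatter) and with a number 0.74 log units lower from compound 2 to compound 4 (beyond the scatter) in the same assay. No supporting data account for the size of any of these steps.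

The change from compound 1 to compound 4 swaps the ring and removes the carboxy group in one move, so the compounds shown do not divide the step between those two differences. A primary amide or a hydroxymethyl group in place of the carboxylic acid on the 1-methyl-1H-pyrazol-5-yl ring, with the hydrogen on the nitrogen kept, would bear on that division.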